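A Methylphenyl for a Nitrophenyl, Starting from a Limit

The source may report more compounds than this note shows. Statements on the series, on what has been measured and on what is new or still open speak of the compounds shown alone.

Compound 1 `CSCC[C@H](NC(=O)c1ccc(NCc2cncn2Cc2ccc(Cl)cc2)cc1-c1ccccc1)C(=O)O` in a functional assay on NIH3T3 cells (Mus musculus) (on this read-out higher numbers stand for an effect only at larger amounts of compound and lower numbers for an effect already at smaller amounts), gives > 10 uM, a limit of the assay rather than a number.
Compound 2 `COC(=O)[C@H](CCSC)NC(=O)c1ccc(NCc2cncn2Cc2cccc([N+](=O)[O-])c2)cc1-c1ccccc1` gives > 10 uM, again a limit.
Compound 3 `CSCC[C@H](NC(=O)c1ccc(NCc2cncn2Cc2ccccc2Cl)cc1-c1ccccc1)C(=O)O` gives > 10 uM, also a limit.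

In this assay compound 2 thus stands at a limit, as do the other two values (the limit of > 10 uM in this assay, at which 3 of the 3 values shown sit). Compound 4 `COC(=O)[C@H](CCSC)NC(=O)c1ccc(NCc2cncn2Cc2ccccc2C)cc1-c1ccccc1` differs from it by 2-methylphenyl in place of 3-nitrophenyl on a saturated chain carbon bound to an aromatic nitrogen. Going by the values given here, the only measured step at one place, a step that the two limits leave unreadable from compound 1 to compound 3, runs between two limits and cannot be sized, so no step bears readably on this change, and no direction beyond the scatter can be expected. Compound 4 is estimated at 20 uM, within 7 uM to 60 uM, most likely again reported as a limit. The expected step is a step that the limit leaves unreadable from compound 2 to compound 4.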

Compound 4, concentration for half-maximal effect: > 10 uM
Compound 4: no number, only a limit; the forecaster's own chance of this, stated with the estimate: 85%; the middle value does not contradict the limit.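

Going by these compounds alone, compound 2 and compound 4 both stand at a limit, so the change from 3-nitrophenyl to 2-methylphenyl gives no step that can be sized: the limit of > 10 uM in this assay, at which 4 of the 4 values shown sit.
In this assay the compounds shown leave open what concentration of any of them gives a half-maximal effect.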